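The compounds below may be only part of what the source reports. "The series", "measured", "known", "first", "only" and "open" are said of these compounds alone.

Measured so far:
compound 1 `C[C@H]1[C@H](NCc2cc(Br)cs2)C[C@H]2C[C@@H]1C2(C)C`: 6250 nM in an ADME assay on MDCK cells (Canis lupus familiaris) for cytotoxicity, read by microscopy, with a stated time of 48 h; on this read-out lower numbers stand for higher toxicity in this test and higher numbers for lower toxicity in this test
compound 2 `Cc1n[nH]cc1CN[C@@H]1C[C@H]2C[C@@H]([C@H]1C)C2(C)C`: > 100000 nM in this assay

The value of compound 2 is a limit of this assay rather than a number (the limit of > 100000 nM in this assay, at which 1 of the 2 values shown sits), so compound 2 stands at the edge of what this test can report. Compound 3 `C[C@H]1[C@H](NCc2ccco2)C[C@H]2C[C@@H]1C2(C)C` differs from compound 2 by furan-2-yl in place of 3-methyl-1H-pyrazol-4-yl on a saturated chain carbon bound to an amine nitrogen. Going by the values given here, the only measured step that bears on this place, an at least 16-fold higher number from compound 1 to compound 2 (1.20 log units; beyond the scatter), also swapped the ring and was large. A ring swap of that kind is therefore expected to move the number again, here downward, by an estimated at least 4.0-fold lower number from compound 2 to compound 3 (0.60 log units; beyond the scatter). Compound 3 is expected at 25000 nM, between 6000 nM and 100000 nM.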

Compound 3, minimum cytotoxic concentration: 50000 nM
Compound 3: the middle estimate sits 2.0-fold (0.30 log units) below what was measured, within the range that was stated.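

Replacing 4-bromothiophen-2-yl with furan-2-yl also raises the number, so a rise at this place does not need a ring with a hydrogen-bond donor: an 8.0-fold higher number from compound 1 to compound 3 (0.90 log units; beyond the scatter). Compound 2 sits at a limit of the test, not at a number: the limit of > 100000 nM in this assay, at which 1 of the 3 values shown sits. The remaining step can therefore only be bounded, an at least 2.0-fold lower number from compound 2 to compound 3 (0.30 log units; that floor lies within the scatter), and the true size of that gap stays unsettled.

Still open, on these data alone, is whether thiophen-2-yl without its bromine would read like compound 1 or like compound 3. As far as these compounds go, what a phenyl ring would give at this place is also open.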